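Allyl to phenyl on a ring nitrogen: paw edema notes

The compounds below may be only part of what the source reports. "The series", "measured", "known", "first", "only" and "open" are said of these compounds alone.

Measured so far, all in a functional assay on the whole organism (strain albino) for inhibition, with Rattus norvegicus as the target, read by paw edema, with a stated time of 5 h, at a dose of 0.28 mmol/kg by the oral route; on this read-out higher numbers stand for more inhibition at the one dose given (going by the name of the read-out) and lower numbers for less inhibition:
compound 1 `C=CCn1c(SCC(=O)c2ccccc2)nnc1-c1ccc(OC)cc1` gives 61%
compound 2 `C=CCn1c(SC/C(=N/O)c2ccccc2)nnc1-c1cc(OC)c(OC)c(OC)c1` gives 77%
compound 3 `COc1ccc(-c2nnc(SCC(=O)c3ccccc3)n2-c2ccccc2)cc1` gives 61%

Compound 1 and compound 3 differ in one place only: phenyl in place of allyl on an aromatic nitrogen. The step that this change made is no change at the digits printed from compound 1 to compound 3 (within the scatter). Compound 2 stands highest of the three numbers; compound 1 and compound 3 sit the same distance under it, and that gap is beyond the scatter. How compound 2 differs from compound 1 is not broken down here, as the two differ in more than one place.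

Compound 4 `COc1cc(-c2nnc(SC/C(=N/O)c3ccccc3)n2-c2ccccc2)cc(OC)c1OC` has not yet been measured in this assay. It differs from compound 2 by phenyl in place of allyl on an aromatic nitrogen. Among the compounds with values here, this is the same kind of change as the one from compound 1 to compound 3, but not the same: there the ring nitrogen sits next to the ring atom that bears a 4-methoxyphenyl group and next to the ring atom that bears a large group, whereas here it sits next to two ring atoms that each bear a large group.

A small step is expected from compound 2 to compound 4, a number 2 percentage points lower from compound 2 to compound 4 (within the scatter), because no change at the digits printed from compound 1 to compound 3 (within the scatter) showed that the same kind of change left the read-out where it was. Within the data shown here, only one earlier instance of the change exists, so the range is kept wide. For compound 4 the expected value in this assay is 75%, estimated to fall between 60% and 88%.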

Compound 4, a percentage reported as inhibition, in the whole organism at one dose (the size of the read-out at that dose, not a potency): 68%
For compound 4 the middle estimate is 7 percentage points above the measured one; the range from low to high includes it.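

In this assay, phenyl in place of allyl on an aromatic nitrogen, now on a second core, gives a number 9 percentage points lower from compound 2 to compound 4 (within the scatter). Set beside the earlier instance, the change carries from one core to the other with no difference in its step that can be told from the scatter: the same change on two cores in this assay, no change at the digits printed (within the scatter) from compound 1 to compound 3 and a number 9 percentage points lower (within the scatter) from compound 2 to compound 4, 9 percentage points apart, within the scatter of two such steps. This does not show that the change is without effect across the series: it rests on two pairs only, each read at a single dose and a single time, and a small real shift could lie hidden within the scatter of either step.

The compounds shown leave open how the read-out responds to other groups on that nitrogen, such as a benzyl group, a saturated chain like propyl, or a phenyl ring carrying an amine or a carboxylic acid. Also open, as far as these compounds go, is whether the two steps would stay alike on a core that keeps the carbonyl of compound 1 while carrying the three methoxy groups of compound 2, or the reverse, since the two cores differ from each other in more than one place.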